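Carbamate substituent variation and PAK 4 inhibition

This account rests on a few compounds, and the source may have more. Where it says the series, first, only, none or still open, it means among the compounds named here.

For the measured compounds named here, compound 2 `C[C@@H]1CN(C(=O)c2nc(Nc3cc(C4CC4)[nH]n3)c3cc(Cl)ccc3n2)CCN1C(=O)OCC(Cl)(Cl)Cl` gives 82.8% in an assay for inhibition of serine/threonine-protein kinase PAK 4 (Homo sapiens), read by FRET and Z'-LYTE, with a stated time of 60 min, tested at 50 uM, in the presence of a further agent that is not named here (a lower number here means a weaker effect, a higher number a stronger effect of the compound at the concentration tested), the higher of the two numbers so far; compound 1 `CC(OC(=O)N1CCN(C(=O)c2nc(Nc3cc(C4CC4)[nH]n3)c3cc(Cl)ccc3n2)C[C@H]1C)OC(=O)C(C)(C)C` gives 65.3% in this assay. Going by the values given here, the one measured step, a number 17.5 percentage points higher from compound 1 to compound 2 (beyond the scatter), shows that the group on this oxygen does move the read-out. Compound 3 `CC(C)OC(=O)N1CCN(C(=O)c2nc(Nc3cc(C4CC4)[nH]n3)c3cc(Cl)ccc3n2)C[C@H]1C` differs from compound 2 by isopropyl in place of 2,2,2-trichloroethyl on an oxygen next to a carbonyl group. That same step is the only one that bears on it; a change of similar, modest size is expected, most likely downward. Compound 3 is therefore estimated at 70%, within 50% to 88%, an expected step of a number 12.8 percentage points lower from compound 2 to compound 3 (beyond the scatter).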

Compound 3, a percentage reported as inhibition, at one concentration (the size of the read-out at that concentration, not a potency): 91.2%
Compound 3: middle estimate off by 21.2 percentage points, on the low side; measured number above the stated range.
By their numbers in this assay, from the lowest: compound 1; then compounds 2 and 3 (each within the scatter of the next).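

In this assay, isopropyl in place of 2,2,2-trichloroethyl gives a number 8.4 percentage points higher from compound 2 to compound 3 (within the scatter) and does not separate these two groups on this oxygen. Methyl in place of ((tert-butyl)carbonyl)oxy gives a number 25.9 percentage points higher from compound 1 to compound 3 (beyond the scatter) and sets compound 1 apart from compound 3 at this position. Nothing available explains either step.

Going by these compounds, how an amine or a longer chain in place of isopropyl would read on this oxygen remains open. A single-concentration read-out also leaves the potency of compound 2 and compound 3 open.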